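Notes on a fluoro-naphthyl pyridinone series, compound 4

A few compounds are considered here, and "the series" means these few. Any claim that something is new, unique, unknown or untested is made for them only; others in the source may bear on it.

Three compounds have been run in a functional assay on CHO cells for antagonist activity at prostaglandin E2 receptor EP3 subtype (Homo sapiens), read by cAMP accumulation; on this read-out lower numbers stand for stronger inhibition and higher numbers for weaker inhibition. Compound 1, `CCn1ncc2c(F)cc(-c3ccc(C(CC)(CC)c4nnc[nH]4)c(=O)[nH]3)cc21`, gives 29 nM in this assay. Compound 3, `CCC(CC)(c1nnc[nH]1)c1ccc(-c2ccc3cccc(F)c3c2)[nH]c1=O`, gives 36 nM. Compound 2, `CC(C)C(c1ccc(-c2ccc3cccc(F)c3c2)[nH]c1=O)N1CCN/C1=N\C#N`, gives 38 nM and carries the highest of the three numbers, but its gap to compound 3 and its gap to compound 1 both lie within the scatter, so the three stand together and no ordering among them can be read.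

Compound 4, `CC(C)C(CC(N)=O)c1ccc(-c2ccc3cccc(F)c3c2)[nH]c1=O`, has not been measured. It differs from compound 2 in one place: a group of 4 heavy atoms (2 carbon, 1 nitrogen, 1 oxygen; no ring) in place of a group of 8 heavy atoms (4 carbon, 4 nitrogen; one five-membered non-aromatic ring with 2 hetero atoms), on a saturated chain carbon bound to an aromatic carbon and a saturated chain carbon. No pair among the measured compounds shows a swap of this kind, so the size of the step is not backed by a shown step. The expectation is a step beyond the scatter toward weaker inhibition, from compound 2 to compound 4 estimated as a 3.9-fold higher number from compound 2 to compound 4 (0.60 log units; beyond the scatter) in this assay. Compound 4 is expected to give about 150 nM in this assay, with a range from 40 nM to 600 nM.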

Compound 4, half-maximal inhibitory concentration: 53 nM
The estimate for compound 4 lay 2.8-fold (0.45 log units) above the measured number; the measured number falls inside the stated range.
By their numbers in this assay, from the lowest: compounds 1, 3, 2 and 4 (each within the scatter of the next).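

At the saturated chain carbon bound to an aromatic carbon and a saturated chain carbon, the series now has its first measured step in this assay: carbamoylmethyl in place of the group with the five-membered non-aromatic ring and the nitrile gives (a 1.4-fold higher number from compound 2 to compound 4 (0.14 log units; within the scatter)). On this core, therefore, neither that ring nor the nitrile is needed for a number within the scatter of that of compound 2, and a group without a ring and with fewer heavy atoms serves at this place. No measurement shown here accounts for the size of this step.

Which part of carbamoylmethyl matters remains open, and a carboxylic acid, a methyl ester, an amine or a longer chain at this place would bear on that. From the compounds shown here alone, whether the same swap gives a similar step on the core of compound 1 is also open.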